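This account rests on a few compounds, and the source may have more. Where it says the series, first, only, none or still open, it means among the compounds named here.

In a functional assay on HCT-116 cells (Homo sapiens) for antiproliferative activity, read by MTT assay, with a stated time of 72 h (a higher number here means a weaker inhibitor, a lower number a stronger inhibitor), compound 1 `NC1=NC2(CCOCC2)N(OCCCOc2cccc(Cl)c2Cl)C(N)=N1` gives 5 nM with a 2,3-dichlorophenyl on an oxygen on a saturated carbon. Among the compounds with values here, compound 2 `Cc1cc(C)cc(OCCCON2C(N)=NC(N)=NC23CCOCC3)c1` gives 190 nM with a 3,5-dimethylphenyl at that place and holds the highest of the two numbers so far, with compound 1 as its nearest neighbour. Compound 3 `NC1=NC2(CCOCC2)N(OCCCOc2ccc(Cl)cc2Cl)C(N)=N1` differs from compound 2 only in that group: 2,4-dichlorophenyl in place of 3,5-dimethylphenyl on an oxygen on a saturated carbon is the difference, with 2,4-dichlorophenyl in place of 3,5-dimethylphenyl. Within the data shown here, one measured step bears on this change: a 38-fold higher number from compound 1 to compound 2 (1.58 log units; beyond the scatter) came with 3,5-dimethylphenyl in place of 2,3-dichlorophenyl, and it is large and beyond the scatter. Among the measured compounds shown here, the entering group is again a dichlorophenyl, but no measured compound carries this one, so that step is expected to be largely, though not fully, reversed. A large drop is therefore expected in this assay and is estimated as a 13-fold lower number from compound 2 to compound 3 (1.10 log units; beyond the scatter) on these two numbers alone. Compound 3 is estimated at 15 nM with an expected range from 4 nM to 60 nM for now.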

Compound 3, half-maximal inhibitory concentration: 880 nM
Compound 3: middle estimate off by 59-fold (1.77 log units), on the low side; the measured number lies above the stated range.
By their numbers in this assay, from the lowest: compound 1; then compound 2; then compound 3.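

In this assay, the name dichlorophenyl alone does not set the result at this place, on an oxygen on a saturated carbon: 2,4-dichlorophenyl in place of 2,3-dichlorophenyl gives a 180-fold higher number from compound 1 to compound 3 (2.25 log units; beyond the scatter), although both groups have the same atom counts. The second change, 2,4-dichlorophenyl in place of 3,5-dimethylphenyl, gives a 4.6-fold higher number from compound 2 to compound 3 (0.67 log units; beyond the scatter), so the group without chlorine ranks between the two dichlorophenyl compounds and the presence of chlorine does not order these three compounds. The position of the two chlorines on the ring therefore matters at least as much here as the exchange of methyl for chlorine, and no measurement shown accounts for any of these differences.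

The compounds shown leave open how a phenyl with a single chlorine, an unsubstituted phenyl or 2,3-dimethylphenyl would compare with these three groups on the same core. Also open, from the compounds shown here alone, is whether the order of 2,3-dichlorophenyl, 3,5-dimethylphenyl and 2,4-dichlorophenyl would persist with a longer chain between the two oxygens.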